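Chloro for trifluoromethyl on the urea aryl ring

A few compounds are considered here, and "the series" means these few. Any claim that something is new, unique, unknown or untested is made for them only; others in the source may bear on it.

Measured compounds:
compound 1, `COc1cc2cc(Oc3ccc(NC(=O)Nc4cccc(C(F)(F)F)c4)cc3)c(C)nc2cc1OC`, > 50000 nM
compound 2, `COc1cc2cc(Oc3ccc(NC(=O)Nc4ccc(Cl)c(C(F)(F)F)c4)cc3)c(C)nc2cc1OC`, 18400 nM

In a functional assay on UACC-62 cells (Homo sapiens) for inhibition, read by sulforhodamine B assay, with a stated time of 48 h (on this read-out higher numbers stand for lower toxicity in this test and lower numbers for higher toxicity in this test), compound 1 reaches only a limit, namely (the limit of > 50000 nM in this assay, at which 1 of the 2 values shown sits). For the measured compounds named here, compound 2 is the one compound with a real number here, giving 18400 nM in this assay. Going by the values given here, the single measured step, an at least 2.7-fold lower number from compound 1 to compound 2 (0.43 log units; beyond the scatter), is the only guide available.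

Compound 3, `COc1cc2cc(Oc3ccc(NC(=O)Nc4ccc(Cl)c(Cl)c4)cc3)c(C)nc2cc1OC`, differs from compound 2 by chloro in place of trifluoromethyl on an aromatic carbon. Among the compounds with values here, no measured step exchanges these two groups against each other; the measured step only adds a chloro next to an existing trifluoromethyl, so it bears on the change from compound 2 to compound 3 indirectly at best. The expectation is therefore a step of a 1.1-fold higher number from compound 2 to compound 3 (0.04 log units; within the scatter) in this assay, not clearly beyond the scatter in either direction. Compound 3 is estimated at 20000 nM, with a range of 8000 nM to 50000 nM.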

Compound 3, concentration lethal to 50% of the cells: 71200 nM
Beside the measured number, compound 3's estimate is 3.6-fold (0.55 log units) below it; measured number above the stated range.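

In this assay, the group ortho to a chloro group on the urea aryl ring clearly affects the read-out: chloro in place of trifluoromethyl gives a 3.9-fold higher number from compound 2 to compound 3 (0.59 log units; beyond the scatter). Compound 2 and compound 3 both carry the chloro that the earlier step introduced, so that chloro alone does not go with the lower number, which appears here only when it is paired with trifluoromethyl. The step between compound 1 and compound 3 cannot be read because compound 1 stands at a limit of the assay: the limit of > 50000 nM in this assay, at which 1 of the 3 values shown sits.

The compounds shown do not tell why trifluoromethyl and chloro differ at this position. On these data alone, it also remains open whether a methyl, a methoxy or a nitrile there would give a number closer to that of compound 2 or compound 3.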